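Dropping a chloro group from a diarylamine inhibitor

This account rests on a few compounds, and the source may have more. Where it says the series, first, only, none or still open, it means among the compounds named here.

Measured so far:
compound 1, `Cc1cc(C)c(Nc2ccc(F)c(F)c2)c(C)c1`, 8700 nM
compound 2, `Cc1cc(C)c(Nc2cc(F)cc(Cl)c2)c(C)c1`, 2900 nM

Both compounds were tested in an assay on isolated protein for binding affinity to Rap guanine nucleotide exchange factor 4 (Homo sapiens), read by cAMP accumulation; a lower number here means a stronger inhibitor, a higher number a weaker inhibitor. Compound 1 gives 8700 nM, and compound 2 gives 2900 nM, the lower of the two numbers; the gap between them lies beyond the usual scatter of repeated measurements, so compound 2 is the stronger inhibitor of the pair. Among the measured compounds shown here, the two differ in more than one place, so no single step connects them.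

Compound 3, `Cc1cc(C)c(Nc2cccc(F)c2)c(C)c1`, has not yet been measured. It differs from compound 2 in one place: hydrogen in place of chloro on an aromatic carbon. The fluoro group stays where it is; only the chloro group is taken away. For the measured compounds named here, with no measured step of this kind to lean on, the expectation rests on the general observation that removing a heavy atom from a small inhibitor more often loosens binding than tightens it. The step from compound 2 to compound 3 is therefore expected to be a 2.1-fold higher number from compound 2 to compound 3 (0.32 log units; beyond the scatter), a modest rise beyond the scatter. For compound 3 in this assay, the expected value is 6000 nM, with a range from 2500 nM to 15000 nM.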

Compound 3, half-maximal inhibitory concentration: 5800 nM
For compound 3 the middle estimate is 1.0-fold (0.01 log units) above the measured one; low and high end bracket the measured number.
By their numbers in this assay, from the lowest: compounds 2, 3 and 1 (each within the scatter of the next, the first and the last beyond it).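

In this assay replacing the chloro group with hydrogen gives a 2.0-fold higher number from compound 2 to compound 3 (0.30 log units; within the scatter) and so stays within the usual scatter of repeated measurements, which means that at this position, meta to a fluoro group, the data cannot tell chloro from hydrogen. Among the compounds shown here, the other step now available, hydrogen in place of a fluoro group on an aromatic carbon, gives a 1.5-fold lower number from compound 1 to compound 3 (0.18 log units; within the scatter) and is also within the scatter, so neither single-atom change on this ring has a measurable effect in this assay so far. No separate measurement on these compounds offers any explanation of these numbers.

As far as these compounds go, these two steps cover only hydrogen, fluoro and chloro on the ring, so it remains open whether a larger or very different group at the chloro position, such as a methoxy group, an amine or a carboxylic acid, would move the number beyond the scatter. From the compounds shown here alone, it is also open whether the same replacement of chloro by hydrogen would give a similar step on a core carrying other groups.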